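The compounds below may be only part of what the source reports. "The series", "measured", "known", "first", "only" and "open" are said of these compounds alone.

Compound 1 `Sc1nnc(-c2ccc3c(c2)OCCO3)n1-c1ccccc1`: 51900 nM
Compound 2 `Clc1ccccc1CSc1nnc(-c2ccc3c(c2)OCCO3)n1-c1ccccc1`: 29000 nM
Compound 3 `Cc1ccccc1CSc1nnc(-c2ccc3c(c2)OCCO3)n1-c1ccccc1`: 36000 nM

All three values come from a functional assay on HeLa cells (Homo sapiens) for antiproliferative activity, read by MTT assay, with a stated time of 24 h; on this read-out lower numbers stand for stronger inhibition and higher numbers for weaker inhibition. Compound 3, at 36000 nM, cannot be told apart from compound 1 or compound 2, as its steps to both lie within the usual scatter of repeated measurements.

Still unmeasured is compound 4 `Brc1ccccc1CSc1nnc(-c2ccc3c(c2)OCCO3)n1-c1ccccc1`. It differs from compound 3 by bromo in place of methyl on an aromatic carbon, ortho to a large group: bromo in place of methyl on an aromatic carbon. Put another way, 2-bromobenzyl replaces 2-methylbenzyl.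

Among the measured compounds shown here, three measured steps bear on this change. Placing a group on the sulfur gave a 1.8-fold lower number from compound 1 to compound 2 (0.25 log units; within the scatter) with 2-chlorobenzyl and a 1.4-fold lower number from compound 1 to compound 3 (0.16 log units; within the scatter) with 2-methylbenzyl. The closest guide is methyl in place of chloro on the aromatic carbon, a 1.2-fold higher number from compound 2 to compound 3 (0.09 log units; within the scatter). For the measured compounds named here, no measured compound carries bromo, so the comparison remains an extrapolation from chloro and methyl.

With the guiding step that small, no change beyond the scatter is expected in this assay. The expected change is a 1.2-fold lower number from compound 3 to compound 4 (0.06 log units; within the scatter). For compound 4 the estimated value is 31000 nM, with an expected range from 15000 nM to 62000 nM.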

Compound 4, half-maximal inhibitory concentration: > 100000 nM
Compound 4: only a limit was reported; the forecaster's own chance of this, stated with the estimate: 5%; at least 3.2-fold (0.50 log units) between middle value and limit.
By their numbers in this assay, from the lowest: compounds 2, 3 and 1 (each within the scatter of the next). At a limit, above all of these: compound 4.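

Compound 4 is reported only as a limit in this assay, not as a number: the limit of > 100000 nM in this assay, at which 1 of the 4 values shown sits.

Even so, this limit gives the only steps in the series that lie beyond the scatter: an at least 2.7-fold higher number from compound 3 to compound 4 (0.44 log units; beyond the scatter) and an at least 3.4-fold higher number from compound 2 to compound 4 (0.53 log units; beyond the scatter). The group on this aromatic carbon, ortho to a large group, can therefore matter, even though chloro and methyl could not be told apart there, and a single heavy atom replaced by another single heavy atom is enough to produce the difference. The comparison with hydrogen on the sulfur is less firm, since an at least 1.9-fold higher number from compound 1 to compound 4 (0.28 log units; that floor lies within the scatter) gives a floor that lies within the scatter, so the limit alone does not separate that pair.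

On these data alone, how far the true value of compound 4 lies past its limit stays open. These numbers do not explain the step. Also open, as far as these compounds go, is whether fluoro or methoxy on the same aromatic carbon would stay with chloro and methyl or move with bromo.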